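The source may hold more compounds than are shown below. What is called first, only, known or untested is meant among the compounds shown, and "the series" means these compounds.

Measured compounds in a functional assay (Homo sapiens) for antiproliferative activity, read by resazurin assay, with a stated time of 48 h, tested at 5 uM; a higher number here means a stronger effect of the compound at the concentration tested, a lower number a weaker effect:
compound 1 `COc1cc(OC)c2c(=O)cc(-c3ccc(OCCF)cc3)oc2c1`; compound 1 gives "not active" (no number reported)
compound 2 `COc1cc(OC)c2c(=O)cc(-c3ccc(OC4CCNCC4)cc3)oc2c1`; compound 2 gives "not active" (no number reported)
compound 3 `COc1cc(OC)c2c(=O)cc(-c3ccc(OCC(O)CN(C)C)cc3)oc2c1`; compound 3 gives 42%

Compound 2 stands without a single number in this assay: its entry is a report of no activity, and the same holds for compound 1, so on the numbers shown compound 2 cannot be set against compound 3, the only member of the series with a figure. Compound 4 `COc1cc(OC)c2c(=O)cc(-c3ccc(NCCN(C)C)cc3)oc2c1` is not yet measured. Its change from compound 2: (2-(dimethylamino)ethyl)amino in place of (piperidin-4-yl)oxy on an aromatic carbon.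

Among the compounds with values here, no step between two measured compounds is available, so the size of the move from compound 2 to compound 4 cannot be read from a neighbouring pair. What the series does show is that compound 2 is reported inactive, while compound 3 gives 42%. The step to compound 4 is therefore expected to be upward and beyond the scatter, with a fair chance that compound 4 too is reported only as not active. Compound 4 is expected to give about 30% in this assay, within 5% to 55%.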

Compound 4, a percentage reported as inhibition, at one concentration (the size of the read-out at that concentration, not a potency): 30%
Compound 4: middle estimate and measured number agree at the digits printed; measured number inside the range.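

At this aromatic carbon, para to a large group, a basic comparison is now possible in this assay: with (piperidin-4-yl)oxy, compound 2 gives "not active" (no number reported), and with (2-(dimethylamino)ethyl)amino, compound 4 gives 30%. Exchanging 3-(dimethylamino)-2-hydroxypropoxy for (2-(dimethylamino)ethyl)amino gives a number 12 percentage points lower from compound 3 to compound 4 (beyond the scatter), so a number is not confined to a single chain at this position, although this change alters the linking atom, the chain and the hydroxyl together. Nothing available bears on the reason for either difference.

The compounds shown do not separate the contribution of the linking nitrogen from that of the hydroxyl. A 2-(dimethylamino)ethoxy chain would isolate the linking atom, and a morpholine in place of the dimethylamino group would test the amine end.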